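A few compounds are considered here, and "the series" means these few. Any claim that something is new, unique, unknown or untested is made for them only; others in the source may bear on it.

Measured so far in a functional assay on KARPAS-299 cells (Homo sapiens) for antiproliferative activity, read by MTT assay, with a stated time of 4 h; a higher number here means a weaker inhibitor, a lower number a stronger inhibitor:
- compound 1 `COc1cc(-n2cccc2C(=O)O)ccc1Nc1ncc(Cl)c(Nc2ccccc2NS(C)(=O)=O)n1`: 90 nM
- compound 2 `CCN1CCN(C(=O)c2cccn2-c2ccc(Nc3ncc(Cl)c(Nc4ccccc4NS(C)(=O)=O)n3)c(OC)c2)CC1`: 1410 nM
- compound 3 `COc1cc(-n2cccc2C(=O)N2CCCC2)ccc1Nc1ncc(Cl)c(Nc2ccccc2NS(C)(=O)=O)n1`: 870 nM

Compound 3 gives the second-highest number of the three in this assay. Its nearest neighbour is compound 2: a 1.6-fold lower number from compound 2 to compound 3 (0.21 log units; within the scatter), a gap within the scatter, so these two are not separated by this assay. The furthest is compound 1: a 9.7-fold higher number from compound 1 to compound 3 (0.99 log units; beyond the scatter), beyond the scatter. Compound 2 stands apart from compound 1 in the same way: a 16-fold higher number from compound 1 to compound 2 (1.19 log units; beyond the scatter). Both replacements of the hydroxy on the carbonyl carbon by an amine thus raise the number; the exchange of one amine for another does not.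

Compound 4 `CCN(CC)C(=O)c1cccn1-c1ccc(Nc2ncc(Cl)c(Nc3ccccc3NS(C)(=O)=O)n2)c(OC)c1` is not yet measured. It differs from compound 3 in one place: diethylamino in place of pyrrolidin-1-yl on a carbonyl carbon. For the measured compounds named here, the only measured step of the same kind, one amine on the carbonyl carbon for another, is that from compound 2 to compound 3, which lies within the scatter. The steps from compound 1 do not bear on it, as no hydroxy is involved. No step beyond the scatter is therefore expected in this assay, in either direction. Compound 4 is expected at 900 nM, with a range of 400 nM to 2500 nM. For compound 4 the expected step is a 1.0-fold higher number from compound 3 to compound 4 (0.01 log units; within the scatter).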

Compound 4, half-maximal inhibitory concentration: 105 nM
Compound 4: middle estimate off by 8.6-fold (0.93 log units), on the high side; the whole stated range lies above it.
By their numbers in this assay, from the lowest: compounds 1 and 4 (each within the scatter of the next); then compounds 3 and 2 (each within the scatter of the next).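

In this assay, the choice of amine on this carbonyl carbon now counts, which the earlier pair of amines did not show: diethylamino in place of pyrrolidin-1-yl, with no ring but the same count of heavy atoms, gives an 8.3-fold lower number from compound 3 to compound 4 (0.92 log units; beyond the scatter), and diethylamino in place of 4-ethylpiperazin-1-yl gives a 13-fold lower number from compound 2 to compound 4 (1.13 log units; beyond the scatter). Replacing hydroxy with an amine on this carbonyl carbon therefore does not always raise the number: compound 4 goes against the trend set by compound 2 and compound 3, with a 1.2-fold higher number from compound 1 to compound 4 (0.07 log units; within the scatter). Nothing available here bears on the reason for these steps.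

From the compounds shown here alone, it remains open whether the absence of a ring is what separates compound 4 from compound 3, or whether the length of the chains also plays a part; piperidin-1-yl, dimethylamino and dipropylamino on the same carbonyl carbon would help to separate these two readings. Also open, going by these compounds, is how ethylamino or an unsubstituted amino group at this place would compare with diethylamino.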